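Phenyl exchange on the ring amine of compound 1

This account rests on a few compounds, and the source may have more. Where it says the series, first, only, none or still open, it means among the compounds named here.

Within the data shown here, in a functional assay on HL-60 cells (Homo sapiens) for inhibition, read by MTT assay, with a stated time of 72 h (a lower number here means a stronger inhibitor, a higher number a weaker inhibitor), compound 1 (`COc1ccc(Cl)cc1N1CCN(C(=O)c2oc(C)nc2-c2ccccc2F)CC1`) gives 153 nM, the lower of the two numbers so far. Compound 2 (`Cc1ccc(C)c(N2CCN(C(=O)c3oc(C)nc3-c3cccc(Cl)c3)CC2)c1`) gives 345 nM, a gap beyond the usual scatter, but this pair differs in more than one place and isolates no single change.

Compound 3 (`C=C(C)c1cccc(N2CCN(C(=O)c3oc(C)nc3-c3ccccc3F)CC2)c1`) keeps the rest of compound 1 and has 3-(1-methylethenyl)phenyl in place of 5-chloro-2-methoxyphenyl on an amine nitrogen in a ring. Among the measured compounds shown here, no measured pair shows this exchange, so the expectation is uncertain. For the measured compounds named here, with compound 1 at 153 nM and compound 2, the only other compound measured, at 345 nM, the expectation leans towards weaker inhibition. The expected change is a 2.6-fold higher number from compound 1 to compound 3 (0.42 log units; beyond the scatter), a moderate step towards a higher number. For compound 3, the estimated value is 400 nM, within an expected range of 130 nM to 1200 nM.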

Compound 3, half-maximal inhibitory concentration: "not active" (no number reported)
The entry for compound 3 holds no number, and the estimate cannot be compared.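

Among these compounds, compound 3 is entered as "not active" without a number in this assay, and no step from compound 1 to compound 3 can be read. No supporting data bear on this result. The compounds shown leave open how far 3-(1-methylethenyl)phenyl in place of 5-chloro-2-methoxyphenyl shifts inhibition.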